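The compounds below may be only part of what the source reports. "The series", "measured", "known", "first", "only" and "open" are said of these compounds alone.

Compound 1, `CC(Br)C(=O)Nc1ccc(C(=O)/C=C/c2ccc(Cl)cc2)cc1`, gives 39% in a functional assay on the whole organism (strain albino) for inhibition, with Rattus norvegicus as the target, read by paw edema, with stated times of 30 min and 1 h, at a dose of 100 mg/kg by the oral route; a lower number here means less inhibition, a higher number more inhibition at the dose given (going by the name of the read-out).
Compound 2, `COc1ccc(/C=C/C(=O)c2ccc(NC(=O)C(C)Br)cc2)cc1`, gives 39% in this assay.
Compound 3, `C/C(=N/O)c1ccc(OCC(=O)Nc2ccc(C(=O)/C=C/c3ccc(Cl)cc3)cc2)cc1`, gives 39% in this assay.

All three measured compounds share a chalcone-type arrangement, and in this assay their readings sit at the same level within the usual scatter. Compound 1 and compound 2 differ in one place only: methoxy in place of chloro on an aromatic carbon. That change gave no change at the digits printed from compound 1 to compound 2 (within the scatter), so swapping these two groups left the read-out where it was. Compound 3 carries a different amide part than compound 1; the difference between the two cores is not broken down here, and what can be said is that their two values show no change within the scatter.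

Compound 4, `COc1ccc(/C=C/C(=O)c2ccc(NC(=O)COc3ccc(/C(C)=N\O)cc3)cc2)cc1`, has not been measured. It differs from compound 3 by methoxy in place of chloro on an aromatic carbon. This is the same change that was made from compound 1 to compound 2, at the same kind of place, on an aromatic carbon of a six-membered aromatic ring of carbon only, para to a large group. Because that earlier change gave no change at the digits printed from compound 1 to compound 2 (within the scatter), the expectation for compound 4 is a step of no change at the digits printed from compound 3 to compound 4 (within the scatter), that is, no change that the scatter would let one see. Compound 4 is therefore estimated to give 39% in this assay, expected to fall between 29% and 49%. This rests on two measured points only, so a larger surprise cannot be ruled out.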

Compound 4, a percentage reported as inhibition, in the whole organism at one dose (the size of the read-out at that dose, not a potency): 33%
The estimate for compound 4 lay 6 percentage points above the measured number; the range from low to high includes it.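

In this assay, methoxy in place of chloro on the aromatic ring gave a number 6 percentage points lower from compound 3 to compound 4 (within the scatter), so this step, like the earlier one, is no larger than the differences seen between repeated measurements. Set side by side, the two steps cannot be told apart, so the swap reads the same on both cores as far as this read-out can show: the same change on two cores in this assay, no change at the digits printed (within the scatter) from compound 1 to compound 2 and a number 6 percentage points lower (within the scatter) from compound 3 to compound 4, 6 percentage points apart, within the scatter of two such steps. Among the compounds shown here, this does not prove that the swap has no effect or that its effect is identical on every core, since there are only two pairs of compounds, each reading is taken at one dose and is not a potency, and a small real difference could stay hidden in the scatter.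

The compounds shown leave open what other groups would do at this place on the ring, for example an amine, a carboxylic acid, or a longer chain such as butoxy in place of methoxy. They also leave open whether chloro and methoxy would still read alike at other doses or on a core with a different amide part from those of compound 1 and compound 3.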